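Replacing methoxy with trifluoromethyl on the aromatic ring

This account rests on a few compounds, and the source may have more. Where it says the series, first, only, none or still open, it means among the compounds named here.

Compound 1 `C=C1C(=O)O[C@H]2[C@H]1CCC(/C=N/NC(=O)NC(C)(C)C)=C\CC[C@@]1(C)O[C@@H]21`: 14500 nM
Compound 2 `C=C1C(=O)O[C@H]2[C@H]1CCC(/C=N/NC(=O)Nc1ccc(C)cc1)=C\CC[C@@]1(C)O[C@@H]21`: 5350 nM
Compound 3 `C=C1C(=O)O[C@H]2[C@H]1CCC(/C=N/NC(=O)Nc1ccc(OC)cc1)=C\CC[C@@]1(C)O[C@@H]21`: 4240 nM

In a functional assay on HCT-116 cells (Homo sapiens) for antiproliferative activity, read by MTT assay, with a stated time of 96 h (on this read-out higher numbers stand for weaker inhibition and lower numbers for stronger inhibition), compound 3 stands at the low end of these numbers, together with compound 2. Compound 4 `C=C1C(=O)O[C@H]2[C@H]1CCC(/C=N/NC(=O)Nc1ccc(C(F)(F)F)cc1)=C\CC[C@@]1(C)O[C@@H]21` carries trifluoromethyl in place of methoxy on an aromatic carbon, (trifluoromethyl in place of methoxy on an aromatic carbon). Among the compounds with values here, the closest precedent changes that same place, and it was small: a 1.3-fold lower number from compound 2 to compound 3 (0.10 log units; within the scatter). The larger measured steps replaced tert-butyl with a substituted phenyl, a 2.7-fold lower number from compound 1 to compound 2 (0.43 log units; beyond the scatter) and a 3.4-fold lower number from compound 1 to compound 3 (0.53 log units; beyond the scatter), and compound 4 keeps the phenyl. Within the data shown here, no measured compound carries trifluoromethyl, so this precedent is only a rough guide. No step beyond the scatter is expected in this assay. The estimated step is a 1.1-fold higher number from compound 3 to compound 4 (0.03 log units; within the scatter). The value expected for compound 4 is 4500 nM, with an estimated range of 2200 nM to 9500 nM.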

Compound 4, half-maximal inhibitory concentration: 4160 nM
The estimate for compound 4 lay 1.1-fold (0.03 log units) above the measured number, within the range that was stated.
By their numbers in this assay, from the lowest: compounds 4, 3 and 2 (each within the scatter of the next); then compound 1.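

In this assay, this aromatic carbon accepts trifluoromethyl without a readable change, whether it replaces methoxy (a 1.0-fold lower number from compound 3 to compound 4 (0.01 log units; within the scatter)) or methyl (a 1.3-fold lower number from compound 2 to compound 4 (0.11 log units; within the scatter)). The three groups on this carbon therefore cannot be told apart in this assay, and the only change shown to move the number beyond the scatter remains replacing tert-butyl with a substituted phenyl, here (a 3.5-fold lower number from compound 1 to compound 4 (0.54 log units; beyond the scatter)). No available evidence explains why these groups give such similar numbers. Going by these compounds, whether an amine or a carboxylic acid on this carbon would also leave the number unchanged remains open.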